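This account rests on a few compounds, and the source may have more. Where it says the series, first, only, none or still open, it means among the compounds named here.

Compound 1 `Nc1nc(NCCNc2ncc(-c3ncc[nH]3)c(-c3ccccc3Cl)n2)ccc1[N+](=O)[O-]` carries a 2-chlorophenyl group on the shared core. In an ADME assay on microsomes from liver (Canis lupus familiaris) for metabolic stability (a higher number here means that the compound lasts longer, a lower number that the compound disappears faster), compound 1 gives > 0.5 h, which is a limit of the assay and not a number. Compound 2 `Nc1nc(NCCNc2ncc(-c3ncc[nH]3)c(-c3ccc(F)cc3C(F)(F)F)n2)ccc1[N+](=O)[O-]` gives > 0.5 h in this assay, again only a limit. Compound 3 `Nc1nc(NCCNc2ncc(-c3ncc[nH]3)c(-c3cc(F)c(Cl)cc3F)n2)ccc1[N+](=O)[O-]` gives > 0.5 h in this assay, a limit as well. The steps a step that the two limits leave unreadable from compound 1 to compound 2, a step that the two limits leave unreadable from compound 1 to compound 3 and a step that the two limits leave unreadable from compound 2 to compound 3 cannot be sized because of the limit of > 0.5 h in this assay, at which 3 of the 3 values shown sit. Compound 4 `Nc1nc(NCCNc2ncc(-c3ncc[nH]3)c(-c3ccc(Br)cc3Cl)n2)ccc1[N+](=O)[O-]` differs from compound 1 by bromo in place of hydrogen on an aromatic carbon. Among the compounds with values here, no measured step bears directly on this change, so the step that the limit leaves unreadable from compound 1 to compound 4 is expected to be small, with no direction beyond the scatter. Compound 4 is therefore expected to give 1 h in this assay, within 0.5 h to 3 h, most likely reported once more as a limit.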

Compound 4, half-life: > 0.5 h
Compound 4: only a limit was reported; the forecaster's own chance of this, stated with the estimate: 75%; the middle value does not contradict the limit.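

Compound 4 gives > 0.5 h, again a limit and not a number. The steps from compound 1, compound 2 and compound 3 to compound 4 cannot be read: the limit of > 0.5 h in this assay, at which 4 of the 4 values shown sit. How long each of these compounds actually lasts in this assay stays open.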